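The source may hold more compounds than are shown below. What is called first, only, known or untested is meant among the compounds shown, and "the series" means these compounds.

For the measured compounds named here, compound 1 `Cc1ccc2ncc(S(=O)(=O)c3ccc(F)cc3)c(N3CCC(C)CC3)c2c1` is one of only two compounds measured in an assay on isolated protein for displacement of a labelled ligand from metabotropic glutamate receptor 5 (Homo sapiens), with a stated time of 60 min, tested at 1 uM; on this read-out lower numbers stand for less inhibition and higher numbers for more inhibition at the one concentration tested (going by the name of the read-out). In this assay compound 1 gives 90%, the higher of the two numbers. Going by the values given here, its single measured neighbour is compound 2 `COc1ccc2ncc(S(=O)(=O)c3ccc(F)cc3)c(N3CCC(C)CC3)c2c1`, which in this assay gives 27%, and the recorded step between them is a number 63 percentage points lower from compound 1 to compound 2 (beyond the scatter), a methoxy in place of methyl on an aromatic carbon of the shared core. The third compound, compound 3 `Cc1ccc2ncc(S(=O)(=O)c3cccc(F)c3)c(N3CCC(C)CC3)c2c1`, has not yet been measured; it differs from compound 1 in one place: 3-fluorophenyl in place of 4-fluorophenyl on a sulfonyl sulfur. Among the compounds with values here, no measured step concerns this kind of change. Within the data shown here, the one step recorded touches the shared core rather than the ring carried on the sulfonyl sulfur. That step does show that a single small change can move this read-out a long way, so the rearrangement in compound 3 cannot simply be assumed to be free of effect. The expected change is a number 20 percentage points lower from compound 1 to compound 3 (beyond the scatter), a modest loss with wide uncertainty. Compound 3 is therefore estimated at 70%, within a range from 35% to 95%.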

Compound 3, a percentage reported as inhibition, at one concentration (the size of the read-out at that concentration, not a potency): 94%
Compound 3: the middle estimate sits 24 percentage points below what was measured; low and high end bracket the measured number.
By their numbers in this assay, from the lowest: compound 2; then compounds 1 and 3 (each within the scatter of the next).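

In this assay, the step on the ring carried by the sulfonyl sulfur is a number 4 percentage points higher from compound 1 to compound 3 (within the scatter), so the 4-fluorophenyl and 3-fluorophenyl compounds cannot be told apart by this read-out. The earlier step, a number 63 percentage points lower from compound 1 to compound 2 (beyond the scatter), showed that one small change on the shared core can matter greatly, whereas this result shows that at least one small change at the sulfonyl sulfur leaves the number within the usual scatter. Nothing available explains why this relocation of the fluorine makes no measurable difference.

The compounds shown leave open whether this position would accept a less similar group, such as unsubstituted phenyl, 3-chlorophenyl or a pyridine ring, in place of the fluorophenyl ring. They also leave open whether compound 1 and compound 3 would still match in potency, since a percentage at one concentration is not a potency and two compounds that both read high at that concentration could still differ when tested across a range of concentrations.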